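The source may report more compounds than this note shows. Statements on the series, on what has been measured and on what is new or still open speak of the compounds shown alone.

Compound 1 `C#CCOC(=O)C[C@@H]1C(C(=O)OC)=CO[C@@H](O[C@@H]2O[C@H](CO)[C@@H](O)[C@H](O)[C@H]2O)/C1=C/C` in a functional assay on SK-BR-3 cells (Homo sapiens) for antiproliferative activity, read by MTT assay, with a stated time of 72 h (on this read-out higher numbers stand for weaker inhibition and lower numbers for stronger inhibition), gives > 15000 nM, a limit of the assay rather than a number.
Compound 2 `C/C=C1/[C@H](O[C@@H]2O[C@H](CO)[C@@H](O)[C@H](O)[C@H]2O)OC=C(C(=O)OC)[C@H]1CC(=O)NCCC` gives in this assay > 20000 nM, again a limit.
Compound 3 `C/C=C1/[C@H](O[C@@H]2O[C@H](CO)[C@@H](O)[C@H](O)[C@H]2O)OC=C(C(=O)OC)[C@H]1CC(=O)OCCc1ccc(F)cc1` gives in this assay > 20000 nM, also a limit.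

Compound 3 therefore stands at the limit of > 20000 nM in this assay, at which 2 of the 3 values shown sit, and compound 2 stands there as well, while compound 1 stands at the limit of > 15000 nM in this assay, at which 1 of the 3 values shown sits. None of the three gives a measured number, so every step among them is unreadable: a step that the two limits leave unreadable from compound 1 to compound 2, a step that the two limits leave unreadable from compound 1 to compound 3 and a step that the two limits leave unreadable from compound 2 to compound 3 all have no readable size.

Compound 4 `C/C=C1/[C@H](O[C@@H]2O[C@H](CO)[C@@H](O)[C@H](O)[C@H]2O)OC=C(C(=O)OC)[C@H]1CC(=O)OCCC(C)C` differs from compound 3 in one place: isopropyl in place of 4-fluorophenyl on a saturated chain carbon, two bonds along the chain from an oxygen next to a carbonyl group. The measured steps that bear on this change are a step that the two limits leave unreadable from compound 1 to compound 3 and a step that the two limits leave unreadable from compound 2 to compound 3, both of which alter the group on the ester side of the carbonyl, and both of which are unreadable because of the two limits. Going by the values given here, no measured step shows that changing this part of the molecule produces activity, and all three measured compounds remain at their limits.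

On that basis compound 4 is expected to remain at a limit as well, with an estimated step that the limit leaves unreadable from compound 3 to compound 4 that is not expected to be beyond scatter. Compound 4 is estimated at 30000 nM, with a range from 15000 nM to 100000 nM.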

Compound 4, half-maximal inhibitory concentration: 9020 nM
Beside the measured number, compound 4's estimate is 3.3-fold (0.52 log units) above it; the measured number lies below the stated range.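

Isopropyl in place of 4-fluorophenyl, on a saturated chain carbon, two bonds along the chain from an oxygen next to a carbonyl group, gives an at least 2.2-fold lower number from compound 3 to compound 4 (0.34 log units; beyond the scatter) in this assay, and with this change the ester side of the carbonyl yields a measured number for the first time among the compounds shown. Isopentyloxy in place of propylamino on a carbonyl carbon gives an at least 2.2-fold lower number from compound 2 to compound 4 (0.34 log units; beyond the scatter), while isobutyl in place of ethynyl gives an at least 1.6-fold lower number from compound 1 to compound 4 (0.22 log units; that floor lies within the scatter), so only the steps from compound 2 and compound 3 clear the scatter. The steps among the three earlier compounds still cannot be read, and compound 2 and compound 3 remain at one limit of the assay: the limit of > 20000 nM in this assay, at which 2 of the 4 values shown sit.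

The compounds shown do not separate the loss of the aromatic ring from the presence of the isopropyl end, a question that an unbranched pentyl chain or a cyclohexyl group in the same place would address. Compound 2 also differs from compound 4 in both its chain and its link to the carbonyl, so an isopentylamino group on that carbonyl carbon would be needed to tell the amide from the ester.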